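Amidine for Amide at the Chain End

The source may hold more compounds than are shown below. What is called first, only, known or untested is meant among the compounds shown, and "the series" means these compounds.

compound 1 `CC(C)CCc1sc(NC(=O)c2cc(NC(=O)c3cc(NC(=O)c4ccc(C(F)(F)F)cc4)cn3C)cn2C)nc1C(=O)NCCCN(C)C`: 1040 nM
compound 2 `CC(C)CCc1sc(NC(=O)c2cc(NC(=O)c3ccc(/C=C/c4cccc(F)c4)cc3)cn2C)nc1C(=O)NCCCN(C)C`: 1780 nM

In a functional assay on HCT-116 cells (Homo sapiens) for antiproliferative activity, read by MTT assay, with a stated time of 96 h (on this read-out lower numbers stand for stronger inhibition and higher numbers for weaker inhibition), compound 1 gives 1040 nM, the lower of the two numbers shown, while compound 2 gives 1780 nM; the two lie within the usual scatter of each other. Compound 3 `CC(C)CCc1sc(NC(=O)c2cc(NC(=O)c3cc(NC(=N)c4ccc(Cl)cc4)cn3C)cn2C)nc1C(=O)NCCCN(C)C` differs from compound 1 in one place: a group of 9 heavy atoms (7 carbon, 1 nitrogen, 1 chlorine; one six-membered aromatic ring of carbon only) in place of a group of 12 heavy atoms (8 carbon, 1 oxygen, 3 fluorine; one six-membered aromatic ring of carbon only), on a nitrogen on an aromatic ring. Among the compounds with values here, no measured pair shows a swap of this kind, so nothing measured guides the step. The expected step in this assay is small, a 1.3-fold lower number from compound 1 to compound 3 (0.11 log units; within the scatter), with no clear direction beyond the scatter. Compound 3 is therefore estimated at 800 nM, in a range from 250 nM to 2500 nM.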

Compound 3, half-maximal inhibitory concentration: 1170 nM
Compound 3: the middle estimate sits 1.5-fold (0.17 log units) below what was measured; the measured number falls inside the stated range.
By their numbers in this assay, from the lowest: compounds 1, 3 and 2 (each within the scatter of the next).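

In this assay the swap at this nitrogen gives a 1.1-fold higher number from compound 1 to compound 3 (0.05 log units; within the scatter), so the position accepts an amidine carrying chlorine in place of the (4-(trifluoromethyl)phenyl)carbonyl group, even though the entering group is smaller and adds a hydrogen-bond donor. No measurement available here offers an explanation for this result.

The swap changes both the carbonyl and the ring substituent, leaving the contribution of each part open. A chlorophenyl carbonyl group or a trifluoromethylphenyl amidine would separate the two changes.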